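The source may report more compounds than this note shows. Statements on the series, on what has been measured and on what is new or still open speak of the compounds shown alone.

Measured compounds and their values:
- Compound 1, `CCC1(Cc2ccccc2)OS(=O)(=O)C=C1OCc1ccc(OC)cc1`: in an ADME assay on HEL cells (Homo sapiens) for cytotoxicity, with a stated time of 3 days (on this read-out higher numbers stand for lower toxicity in this test and lower numbers for higher toxicity in this test), compound 1 gives >= 200000 nM, a limit of the assay and not a number.
- Compound 2, `CCC1(Cc2ccccc2)OS(=O)(=O)C=C1OCc1ccc(Cl)cc1`: in this assay compound 2 gives >= 50000 nM, also a limit.
- Compound 3, `CCC1(Cc2ccccc2)OS(=O)(=O)C=C1OCc1ccc([N+](=O)[O-])cc1`: in this assay compound 3 gives >= 80000 nM, also a limit.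

Compound 3 thus stands only at a limit, and the other two values shown are limits as well: the limit of >= 200000 nM in this assay, at which 1 of the 3 values shown sits, the limit of >= 50000 nM in this assay, at which 1 of the 3 values shown sits, and (the limit of >= 80000 nM in this assay, at which 1 of the 3 values shown sits). For that reason none of the measured steps can be sized: a step that the two limits leave unreadable from compound 1 to compound 3 and a step that the two limits leave unreadable from compound 2 to compound 3 are both unreadable, as is a step that the two limits leave unreadable from compound 1 to compound 2.

Compound 4, `CCC1(Cc2ccccc2)OS(=O)(=O)C=C1OCc1ccc(Cl)c(Cl)c1`, differs from compound 3 by one change: 3,4-dichlorophenyl in place of 4-nitrophenyl on a saturated chain carbon bound to an oxygen on an unsaturated carbon. The measured steps that bear on it are the two ending at compound 3, and both are unreadable, so no direction or size of step in this assay can be drawn from them. The expectation is that compound 4 again falls at a limit, with the step of an at least 1.3-fold lower number from compound 3 to compound 4 (0.12 log units; that floor lies within the scatter) expected to lie within the scatter. Compound 4 is therefore estimated at 60000 nM, expected to lie between 15000 nM and 200000 nM.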

Compound 4, minimum cytotoxic concentration: >= 20000 nM
Compound 4: a limit, no number (the forecaster's own chance of this, stated with the estimate: 70%); the middle value is on the limit's open side.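

In this assay compound 4 gives >= 20000 nM, again a limit and not a number. The steps to it from compound 1, compound 2 and compound 3 cannot be read. Still open, as far as these compounds go, is the actual concentration at which any of these four compounds becomes toxic, and whether changing the aromatic ring's groups shifts it.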